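The source may report more compounds than this note shows. Statements on the series, on what has been measured and on what is new or still open speak of the compounds shown alone.

Compound 1 `O=[N+]([O-])c1ccccc1NC(CO)CO`: in a functional assay on SW1990 cells (Homo sapiens) for cytotoxicity (on this read-out higher numbers stand for weaker inhibition and lower numbers for stronger inhibition), compound 1 gives > 100000 nM, which is a limit of the assay and not a number.
Compound 2 `O=[N+]([O-])c1ccc(NC(CO)CO)c([N+](=O)[O-])c1`: in this assay compound 2 gives > 100000 nM, again a limit.
Compound 3 `O=[N+]([O-])c1cc(C(F)(F)F)ccc1NC(CO)CO`: in this assay compound 3 gives > 100000 nM, again a limit.

Compound 2 stands at a limit only, as do the two other values shown; all three sit at the limit of > 100000 nM in this assay, at which 3 of the 3 values shown sit. The step to compound 4 `O=[N+]([O-])c1ccc(NC(CO)CO)c(C(F)(F)F)c1` is trifluoromethyl in place of nitro on an aromatic carbon. The same exchange was made between compound 2 and compound 3, where a step that the two limits leave unreadable from compound 2 to compound 3; the steps a step that the two limits leave unreadable from compound 1 to compound 2 and a step that the two limits leave unreadable from compound 1 to compound 3 are likewise unreadable. Among the measured compounds shown here, no step in this assay therefore gives a size or direction for this exchange. The expected step is a number no higher from compound 2 to compound 4 (the limit leaves the size open), which would be no step beyond the scatter, with compound 4 most likely again sitting at the limit. Compound 4 is estimated at 100000 nM, within 30000 nM to 300000 nM.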

Compound 4, half-maximal inhibitory concentration: > 100000 nM
Compound 4 gave a limit, no number; the forecaster's own chance of this, stated with the estimate: 85%; the middle value lies on the limit itself.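

Compound 4 gives > 100000 nM in this assay, a limit and not a number. No step can be read between compound 2 and compound 4, nor between any other pair: the limit of > 100000 nM in this assay, at which 4 of the 4 values shown sit.

The compounds shown leave open whether any exchange on the shared core changes the read-out in this assay, and in which direction.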